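The compounds below may be only part of what the source reports. "The series", "measured", "known", "first", "only" and "open" are said of these compounds alone.

Working notes on the series. In a functional assay on MCF7 cells (Homo sapiens) for antiproliferative activity, read by sulforhodamine B assay, with a stated time of 48 h (on this read-out higher numbers stand for weaker inhibition of growth and lower numbers for stronger inhibition of growth), compound 1 `O=C(NCc1cn(Cc2ccc(C(F)(F)F)cc2)nn1)c1cn(-c2ccccc2)nc1-c1ccccc1` gives 840 nM and compound 3 `COc1cc(Cn2cc(CNC(=O)c3cn(-c4ccccc4)nc3-c3ccccc3)nn2)cc(OC)c1` gives 2400 nM. Compound 2 `COc1ccc(Cn2cc(CNC(=O)c3cn(-c4ccccc4)nc3-c3ccccc3)nn2)cc1` reads > 100000 nM, which is a limit of the assay and not a number. Compound 3 therefore holds the higher of the two true numbers, and compound 1 is its nearest neighbour.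

Compound 4 `COc1cc(Cn2cc(CNC(=O)c3cn(-c4ccccc4)nc3-c3ccc(Cl)cc3)nn2)cc(OC)c1` carries the change chloro in place of hydrogen on an aromatic carbon, phenyl to 4-chlorophenyl. Within the data shown here, no measured step touches this place, so none bears on it directly. All three alter the aryl group elsewhere in the molecule: the large at least 110-fold higher number from compound 1 to compound 2 (2.07 log units; beyond the scatter), the modest 2.9-fold higher number from compound 1 to compound 3 (0.46 log units; beyond the scatter) and the large at least 41-fold lower number from compound 2 to compound 3 (1.61 log units; beyond the scatter). They show that single changes can move the number in this assay sharply, but they give no direction for this one. No step beyond the scatter is therefore expected, though with wide uncertainty, and the expected step is a 1.2-fold lower number from compound 3 to compound 4 (0.08 log units; within the scatter). For compound 4, the estimated value is 2000 nM, with an expected range of 350 nM to 12000 nM.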

Compound 4, concentration for 50% growth inhibition: 150 nM
For compound 4 the middle estimate is 13-fold (1.12 log units) above the measured one; the measured number lies below the stated range.
By their numbers in this assay, from the lowest: compound 4; then compound 1; then compound 3. At a limit, above all of these: compound 2.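

Phenyl to 4-chlorophenyl gives a 16-fold lower number from compound 3 to compound 4 (1.20 log units; beyond the scatter) in this assay, the first step shown at this aryl group, which compounds 1, 2 and 3 all carry unchanged. Among these compounds, this position is therefore sensitive as well: the earlier steps all lay in the other aryl group, and here a single chlorine atom on an aromatic carbon, para to a large group, lowers the number beyond the scatter. Nothing measured in the compounds shown gives a cause for this step.

Chloro is shown at this place only with the 3,5-dimethoxyphenyl group of compound 3, so it remains open whether the same lowering holds with the 4-(trifluoromethyl)phenyl group of compound 1. Also open, from the compounds shown here alone, is how fluoro, bromo, methoxy or an amine would read at this carbon, and how chloro would read elsewhere on this ring.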